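The compounds below may be only part of what the source reports. "The series", "measured", "known", "first", "only" and "open" are said of these compounds alone.

Measured compounds:
Compound 1 `COc1cccc(C(=O)Nc2nn[nH]n2)n1`: 58%
Compound 2 `O=C(Nc1nn[nH]n1)c1ccccn1`: 35%

In a functional assay on the whole organism for inhibition, with Rattus norvegicus as the target, at a dose of 10 mg/kg by the oral route (on this read-out higher numbers stand for a stronger effect at the one dose given and lower numbers for a weaker effect), compound 2 gives 35%, the lower of the two numbers, while compound 1 gives 58%. Compound 3 `CCCCOc1cccc(C(=O)Nc2nn[nH]n2)n1` differs from compound 2 by butoxy in place of hydrogen on an aromatic carbon. Going by the values given here, the only measured step that bears on this change is a number 23 percentage points lower from compound 1 to compound 2 (beyond the scatter), which shows that a group entering at this place can raise the number beyond the scatter. Since butoxy enters at this place in compound 3, a rise of similar size is expected, a number 20 percentage points higher from compound 2 to compound 3 (beyond the scatter). Compound 3 is therefore estimated to give 55%, within a range from 30% to 80%.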

Compound 3, a percentage reported as inhibition, in the whole organism at one dose (the size of the read-out at that dose, not a potency): 8%
The estimate for compound 3 lay 47 percentage points above the measured number; measured number outside the range, below it.
By their numbers in this assay, from the lowest: compound 3; then compound 2; then compound 1.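

In this assay butoxy on this aromatic carbon brings a number 27 percentage points lower from compound 2 to compound 3 (beyond the scatter), so an oxygen-linked chain here does not always raise the number as methoxy does. Lengthening the chain on that oxygen, with propyl in place of hydrogen, brings a number 50 percentage points lower from compound 1 to compound 3 (beyond the scatter) and turns a gain into a loss. The outcome at this place therefore depends on what the oxygen carries, and nothing shown here explains the drop. Where between methoxy and butoxy the number turns down remains open, as ethoxy and propoxy are not among the compounds shown. On these data alone, how an amine or a chlorine would behave on this carbon is also open.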